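Thiadiazole oxide in place of nitroethene: series notes

The source may report more compounds than this note shows. Statements on the series, on what has been measured and on what is new or still open speak of the compounds shown alone.

Measured so far:
compound 1 `C/N=C(\NC#N)Nc1cccc(-c2[nH]cnc2C)c1` — 39800 nM
compound 2 `CN/C(=C\[N+](=O)[O-])Nc1cccc(-c2[nH]cnc2C)c1` — 15800 nM
compound 3 `CN/C(=C/[N+](=O)[O-])Nc1cccc(-c2csc(N=C(N)N)n2)c1` — 200 nM

In an assay on cardiac atrium for inhibition of histamine H2 receptor (Cavia porcellus) (a lower number here means a stronger inhibitor, a higher number a weaker inhibitor), compound 3 holds the lowest of the three numbers; its gaps to compound 2 and to compound 1 both lie beyond the scatter, so on these values compound 3 is the strongest inhibitor of the set. Among the compounds with values here, no pair of measured compounds differs in a single place, so no measured step is available.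

Compound 4 `CNc1n[s+]([O-])nc1Nc1cccc(-c2csc(N=C(N)N)n2)c1` differs from compound 3 by a group of 8 heavy atoms (3 carbon, 3 nitrogen, 1 oxygen, 1 sulfur; one five-membered aromatic ring with 3 hetero atoms) in place of a group of 7 heavy atoms (3 carbon, 2 nitrogen, 2 oxygen; no ring), on a nitrogen on an aromatic ring. Nothing measured here shows what such an exchange does. Compound 4 is expected to stay close to compound 3, with the step of a 1.5-fold lower number from compound 3 to compound 4 (0.19 log units; within the scatter) expected not to exceed the scatter by much. The estimate for compound 4 is 130 nM, range 30 nM to 600 nM.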

Compound 4, inhibition constant: 398 nM
Beside the measured number, compound 4's estimate is 3.1-fold (0.49 log units) below it, within the range that was stated.
By their numbers in this assay, from the lowest: compounds 3 and 4 (each within the scatter of the next); then compound 2; then compound 1.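

In the assay this assay the five-membered aromatic ring with 3 hetero atoms, taking the place of the open group of 7 heavy atoms, gives a 2.0-fold higher number from compound 3 to compound 4 (0.30 log units; within the scatter) on a nitrogen on an aromatic ring. This position therefore accepts a ring as well as the open group, with the shared core held constant. Nothing available accounts for this result.

Still open, as far as these compounds go, is how the same ring reads on the core of compound 1 or compound 2, and what a longer chain or a carboxylic acid would do on that ring.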